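Thiophene for phenyl on the E-configured arylidene

The source may report more compounds than this note shows. Statements on the series, on what has been measured and on what is new or still open speak of the compounds shown alone.

Measured so far in an ADME assay on NIH3T3 cells (Homo sapiens) for cytotoxicity, read by sulforhodamine B assay, with a stated time of 48 h; on this read-out higher numbers stand for weaker inhibition and lower numbers for stronger inhibition:
Compound 1, `CC(=O)OC[C@H]1O[C@@H](n2cc(CN3C(=O)/C(=C\c4ccccc4)c4ccccc43)nn2)[C@H](OC(C)=O)[C@@H](OC(C)=O)[C@@H]1OC(C)=O`: 22800 nM
Compound 2, `CC(=O)OC[C@H]1O[C@@H](n2cc(CN3C(=O)/C(=C/c4ccccc4)c4ccccc43)nn2)[C@H](OC(C)=O)[C@@H](OC(C)=O)[C@@H]1OC(C)=O`: > 100000 nM

Compound 2 stands at the limit of this assay; its value is a limit, not a number. Compound 1 has the same atoms and bonds and differs from compound 2 only in configuration as drawn; in this assay compound 1 gives 22800 nM, and the step of an at least 4.3-fold higher number from compound 1 to compound 2 (0.64 log units; beyond the scatter) is beyond the scatter. This step rests on the limit of > 100000 nM in this assay, at which 1 of the 2 values shown sits, and (the fact that compounds 1 and 2 differ only in the configuration as drawn).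

Compound 3, `CC(=O)OC[C@H]1O[C@@H](n2cc(CN3C(=O)/C(=C/c4cccs4)c4ccccc43)nn2)[C@H](OC(C)=O)[C@@H](OC(C)=O)[C@@H]1OC(C)=O`, keeps the configuration of compound 2 and differs from it by thiophen-2-yl in place of phenyl on a double-bonded chain carbon bound to a double-bonded ring carbon. For the measured compounds named here, no measured step involves a change of this aryl group; the only measured step concerns the geometry of the double bond, which compound 3 shares with compound 2. There is therefore no basis for expecting a step beyond the scatter in this assay. Compound 3 is expected to sit near the limit, with an expected step of a number no higher from compound 2 to compound 3 (the limit leaves the size open). Compound 3 is estimated at 100000 nM, in the range 30000 nM to 300000 nM.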

Compound 3, half-maximal inhibitory concentration: 48100 nM
Compound 3: middle estimate off by 2.1-fold (0.32 log units), on the high side; low and high end bracket the measured number.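

Up to compound 2, the only measured change was the geometry of the double bond; compound 3 shows that the aryl group on a double-bonded chain carbon bound to a double-bonded ring carbon also counts in this assay. For the compounds shown here, with the E-drawn double bond kept, thiophen-2-yl in place of phenyl gives an at least 2.0-fold lower number from compound 2 to compound 3 (0.31 log units; beyond the scatter), which brings this geometry off the limit of the assay and gives it a measured number for the first time. Compound 2 remains a limit, > 100000 nM, and not a number, so the true size of this step stays open: the limit of > 100000 nM in this assay, at which 1 of the 3 values shown sits.

The compounds shown leave open whether thiophen-2-yl would move the number in the same direction on the Z-drawn double bond of compound 1, and what other groups at this place, such as furan-2-yl or a phenyl carrying an amine or a carboxylic acid, would do. They also give no reason for the step, and they do not tell whether hydroxyl groups in place of the acetate esters would change the picture.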